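The source may report more compounds than this note shows. Statements on the series, on what has been measured and on what is new or still open speak of the compounds shown alone.

Compounds measured in an assay on isolated protein for inhibition of Voltage-dependent L-type calcium channel subunit alpha-1C (Cavia porcellus); on this read-out lower numbers stand for stronger inhibition and higher numbers for weaker inhibition:
compound 1, `CC1=C(C(=O)OCC2CCCCC2)C(c2[nH]cnc2Cl)C(C(=O)OCC2CCCCC2)=C(C)N1`, 631 nM
compound 2, `CCOC(=O)C1=C(C)NC(C)=C(C(=O)OC)C1c1[nH]cnc1Cl`, 661 nM
compound 3, `COC(=O)C1=C(C)NC(C)=C(C(=O)OC(C)(C)C)C1c1[nH]cnc1Cl`, 1860 nM

Among these three, compound 3 gives the highest number in this assay, and its steps to both neighbours are beyond the scatter: compound 2 stands closest, and compound 1, with two cyclohexylmethyl esters, gives a number of about the same size as compound 2. Among the measured compounds shown here, the one single-point step that is known, a 2.8-fold higher number from compound 2 to compound 3 (0.45 log units; beyond the scatter), shows that a bulkier group on the ester oxygen raised the number by a modest amount.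

Compound 4, `COC(=O)C1=C(C)NC(C)=C(C(=O)OCC2CCCCC2)C1c1[nH]cnc1Cl`, has not yet been measured. Relative to compound 3 the change is cyclohexylmethyl in place of tert-butyl on an oxygen next to a carbonyl group. The step from compound 2 to compound 3 bears on it only in reverse, since it removes the tert-butyl group; compound 1 shows that cyclohexylmethyl esters give a number close to that of compound 2. A modest step back toward lower numbers is therefore expected in this assay, and compound 4 is estimated at 700 nM (range 300 nM to 1600 nM), that is, a step of a 2.7-fold lower number from compound 3 to compound 4 (0.42 log units; beyond the scatter) is expected.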

Compound 4, half-maximal inhibitory concentration: 355 nM
For compound 4 the middle estimate is 2.0-fold (0.29 log units) above the measured one; low and high end bracket the measured number.
By their numbers in this assay, from the lowest: compounds 4, 1 and 2 (each within the scatter of the next); then compound 3.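

In this assay, cyclohexylmethyl in place of tert-butyl on an oxygen next to a carbonyl group gives a 5.2-fold lower number from compound 3 to compound 4 (0.72 log units; beyond the scatter) at this ester, so adding heavy atoms here does not by itself raise the number: this step and the earlier one (a 2.8-fold higher number from compound 2 to compound 3 (0.45 log units; beyond the scatter)) both add heavy atoms yet run in opposite directions. Ethyl and cyclohexylmethyl cannot be told apart at this place (a 1.9-fold lower number from compound 2 to compound 4 (0.27 log units; within the scatter)), which leaves tert-butyl as the only one of the three groups that stands out. Methyl and cyclohexylmethyl on the other ester likewise cannot be told apart (a 1.8-fold lower number from compound 1 to compound 4 (0.25 log units; within the scatter)).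

From the compounds shown here alone, whether a longer chain, an amine on the chain or a carboxylic acid in place of the ester would follow the same course remains open. Nothing at hand accounts for these differences.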